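The source may hold more compounds than are shown below. What is called first, only, known or untested is meant among the compounds shown, and "the series" means these compounds.

Measured compounds in an assay on isolated protein for inhibition of legumain (Homo sapiens), with stated times of 2 min and 60 min; on this read-out higher numbers stand for weaker inhibition and lower numbers for stronger inhibition:

- compound 1 `CC(C)Oc1cccc(-c2ccc(CN([C@H](C)C(=O)N[C@H](C#N)CC(N)=O)S(C)(=O)=O)cc2)c1`: 5050 nM
- compound 2 `CCC[C@@H](C(=O)N[C@H](C#N)CC(N)=O)N(Cc1ccc(-c2cccc(F)c2F)cc1)S(C)(=O)=O`: 7750 nM

Compound 1 holds the lower of the two numbers, but its gap to compound 2 lies within the scatter, so the two are not told apart on this read-out.

Compound 3 `C[C@H](C(=O)N[C@H](C#N)CC(N)=O)N(Cc1ccc(-c2ccc(F)cc2)cc1)S(C)(=O)=O` has not yet been measured in this assay. Against compound 1 it shows (4-fluorophenyl in place of 3-isopropoxyphenyl on an aromatic carbon). For the measured compounds named here, no two measured compounds differ in this place alone, so no measured step speaks directly to the change. What the data show is that compound 1 and compound 2, with different aryl termini and different side chains, land close together; that gives no ground to expect a large move. The step from compound 1 to compound 3 is expected to be small, at most a modest loss of potency, estimated as a 1.4-fold higher number from compound 1 to compound 3 (0.14 log units; within the scatter). For compound 3 the value in this assay is therefore estimated at 7000 nM, within 2500 nM to 20000 nM.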

Compound 3, half-maximal inhibitory concentration: > 10000 nM
Compound 3 gave a limit, no number (the forecaster's own chance of this, stated with the estimate: 10%); middle value at least 1.4-fold (0.15 log units) from the limit.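

In this assay, for the compounds shown here, the change to 4-fluorophenyl in place of 3-isopropoxyphenyl gives the only step that differs in one place: an at least 1.9-fold higher number from compound 1 to compound 3 (0.29 log units; that floor lies within the scatter). The result for compound 3 is a limit of the assay and not a number, so this step has a floor but no measured size: the limit of > 10000 nM in this assay, at which 1 of the 3 values shown sits. That floor does not establish a loss at this aromatic carbon, yet the change shows no sign of a gain.

Going by these compounds, the true value of compound 3 remains open, as does how much of the step belongs to losing the isopropoxy group and how much to adding the fluorine. The compounds shown also do not tell how an unsubstituted phenyl, an amine or a carboxylic acid in the same place would compare with compound 1.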